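Series notes: styrylsulfonamide cytotoxicity, step to compound 4

The source may report more compounds than this note shows. Statements on the series, on what has been measured and on what is new or still open speak of the compounds shown alone.

Compound 1 `COc1ccc(NS(=O)(=O)/C=C/c2c(F)c(F)c(F)c(F)c2F)cc1N` gives 75000 nM in a functional assay on DU-145 cells (Homo sapiens) for cytotoxicity, read by trypan blue exclusion, with a stated time of 96 h (on this read-out higher numbers stand for weaker inhibition and lower numbers for stronger inhibition), and compound 2 `COc1ccc(/C=C/S(=O)(=O)Nc2ccc(F)cc2)cc1` gives 10000 nM there. Compound 3 `COC(=O)C(C)(C)Nc1cc(NS(=O)(=O)/C=C/c2c(OC)cc(OC)cc2OC)ccc1OC` gives 200 nM in this assay, the lowest of the three numbers and the strongest inhibitor, since its gap to each of the others lies beyond the scatter. Compound 4 `COc1cc(OC)c(/C=C/S(=O)(=O)Nc2ccc(OC)c(NC(C(=O)O)c3ccc(Cl)cc3)c2)c(OC)c1` is not yet measured. It differs from compound 3 in one place: carboxy(4-chlorophenyl)methyl in place of 1-(methoxycarbonyl)-1-methylethyl on a nitrogen on an aromatic ring. Within the data shown here, no measured pair reports this change, so its effect is unknown. Compound 4 is expected to stay near compound 3, with the step from the latter a 2.0-fold higher number from compound 3 to compound 4 (0.30 log units; within the scatter) estimated as small and, if anything, toward weaker inhibition. Compound 4 is therefore estimated at 400 nM, within 100 nM to 2000 nM.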

Compound 4, half-maximal inhibitory concentration: 75 nM
Compound 4: middle estimate off by 5.3-fold (0.73 log units), on the high side; measured number below the stated range.
By their numbers in this assay, from the lowest: compound 4; then compound 3; then compound 2; then compound 1.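

On a nitrogen on an aromatic ring, carboxy(4-chlorophenyl)methyl in place of 1-(methoxycarbonyl)-1-methylethyl gives a 2.7-fold lower number from compound 3 to compound 4 (0.43 log units; beyond the scatter) in this assay, so this position tolerates a larger group with an aromatic ring and a carboxy group without loss of inhibition. The change alters several features at once, so the step belongs to the whole group and not to any one part. No measurement on hand accounts for the step.

From the compounds shown here alone, whether the carboxy group or the 4-chlorophenyl ring carries the step stays open. A plain phenyl or a methyl ester within the same group would separate the two.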